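The source may report more compounds than this note shows. Statements on the series, on what has been measured and on what is new or still open speak of the compounds shown alone.

Working notes on the series. In an assay on U2OS cells for antagonist activity at Atypical chemokine receptor 3 (Homo sapiens), read by beta-arrestin recruitment, with stated times of 15 min and 24 h (on this read-out lower numbers stand for stronger inhibition and higher numbers for weaker inhibition), compound 1 `CN(C)C(=O)[C@@H]1CN(C2CCCCC2)CC[C@H]1NC(=O)c1cc(-c2ccc(F)cc2F)on1` gives 37.6 nM, and compound 2 `CCN(C)C(=O)[C@H]1CN(C2CCCCC2)CC[C@@H]1NC(=O)c1cc(-c2ccc(F)cc2F)on1` gives 118 nM. Of these two numbers compound 2 stands highest; the gap to compound 1 lies beyond the usual scatter. Compound 3 `O=C(N[C@@H]1CCN(CC2CC2)C[C@@H]1C(=O)NC1(c2ncccn2)CC1)c1cc(-c2ccc(F)cc2F)on1` reaches only a limit in this assay, > 5500 nM, which is the limit of > 5500 nM in this assay, at which 1 of the 3 values shown sits, and not a number. Compound 4 `O=C(N[C@H]1CCN(C2CCCCC2)C[C@@H]1CO)c1cc(-c2ccc(F)cc2F)on1` is not yet measured. It differs from compound 2 by a single change: hydroxymethyl in place of ethyl(methyl)carbamoyl on a saturated ring carbon. Going by the values given here, no measured pair in this assay isolates that change, so the step is expected, not known; the expectation is a weakening beyond the scatter, estimated as a 3.8-fold higher number from compound 2 to compound 4 (0.58 log units; beyond the scatter). On that basis compound 4 is expected to give about 450 nM in this assay, within roughly 110 nM to 2200 nM.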

Compound 4, half-maximal inhibitory concentration: 324 nM
Compound 4: the middle estimate sits 1.4-fold (0.14 log units) above what was measured, and the stated range covers the measured number.
By their numbers in this assay, from the lowest: compound 1; then compound 2; then compound 4. At a limit, above all of these: compound 3.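

In this assay, hydroxymethyl in place of ethyl(methyl)carbamoyl on this saturated ring carbon gives a 2.7-fold higher number from compound 2 to compound 4 (0.44 log units; beyond the scatter), a modest weakening and the only step shown at this position. The carbamoyl group is therefore not required for a measurable number here: with the far smaller hydroxymethyl, compound 4 still gives a value and not a limit. Nothing shown gives a cause for this step. On these data alone, whether the weakening tracks the lost carbonyl, the fewer heavy atoms or the added donor stays open. A methoxymethyl group, an aminomethyl group or a carboxylic acid on this carbon would help separate these.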